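The source may hold more compounds than are shown below. What is called first, only, known or untested is meant among the compounds shown, and "the series" means these compounds.

Measured compounds:
- compound 1 `COc1ccc(/C=C/c2cc(OC)cc(OC)c2/C=C/C(=O)NC2CC2)cc1`: 3940 nM
- compound 2 `COc1ccc(/C=C/c2cc(OC)cc(OC)c2/C=C/C(=O)N2CCCCC2C)cc1`: 4350 nM
- compound 3 `CCC(C)NC(=O)/C=C/c1c(/C=C/c2ccc(OC)cc2)cc(OC)cc1OC`: 3430 nM

All three were tested in a functional assay on MCF7 cells (Homo sapiens) for inhibition, read by MTT assay, with a stated time of 48 h; on this read-out lower numbers stand for stronger inhibition and higher numbers for weaker inhibition. The number for compound 1 lies alongside those of compound 2 and compound 3, and none of the steps among them leaves the scatter: a 1.1-fold higher number from compound 1 to compound 2 (0.04 log units; within the scatter), a 1.1-fold lower number from compound 1 to compound 3 (0.06 log units; within the scatter) and a 1.3-fold lower number from compound 2 to compound 3 (0.10 log units; within the scatter). Compound 4 `COc1ccc(/C=C/c2cc(OC)cc(OC)c2/C=C/C(=O)N2CCCC(C)C2)cc1` has not yet been measured. It differs from compound 1 in one place: 3-methylpiperidin-1-yl in place of cyclopropylamino on a carbonyl carbon. Within the data shown here, the step that bears on this most closely is the one to compound 2, where 2-methylpiperidin-1-yl likewise stood in place of cyclopropylamino on the carbonyl carbon and the number stayed within the scatter, as a 1.1-fold higher number from compound 1 to compound 2 (0.04 log units; within the scatter) shows. No step beyond the scatter is therefore expected, a 1.1-fold higher number from compound 1 to compound 4 (0.03 log units; within the scatter). Compound 4 is estimated at 4200 nM, with a range from 2000 nM to 8500 nM.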

Compound 4, half-maximal inhibitory concentration: 11900 nM
For compound 4 the middle estimate is 2.8-fold (0.45 log units) below the measured one, outside the stated range (above it).
By their numbers in this assay, from the lowest: compounds 3, 1 and 2 (each within the scatter of the next); then compound 4.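

In this assay the group on the carbonyl carbon can matter after all: 3-methylpiperidin-1-yl gives a 3.0-fold higher number from compound 1 to compound 4 (0.48 log units; beyond the scatter) and a 3.5-fold higher number from compound 3 to compound 4 (0.54 log units; beyond the scatter), although the earlier changes at this place all stayed within the scatter. The result also shows a 2.7-fold higher number from compound 2 to compound 4 (0.44 log units; beyond the scatter), so 3-methylpiperidin-1-yl and 2-methylpiperidin-1-yl are not interchangeable here, even though both replace cyclopropylamino on the same carbonyl carbon. No available evidence explains this difference.

The compounds shown leave open how a piperidine without a methyl, or a morpholine, would behave at this carbonyl carbon.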